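Dimethylamino to acetyl on the pendant phenyl of compound 1

A few compounds are considered here, and "the series" means these few. Any claim that something is new, unique, unknown or untested is made for them only; others in the source may bear on it.

Measured so far in a functional assay on HCT-116 cells (Homo sapiens) for inhibition, read by sulforhodamine B assay, with a stated time of 48 h; on this read-out higher numbers stand for lower toxicity in this test and lower numbers for higher toxicity in this test:
compound 1 `COc1cc(C)cc(-c2c(-c3ccnc(-c4ccc(N(C)C)cc4)c3)cnn2CC#N)c1`, > 100000 nM
compound 2 `COc1cc(C)cc(-c2nn(CC#N)cc2-c2ccnc(-c3ccc(N(C)C)cc3)c2)c1`, > 100000 nM
compound 3 `Cc1cc(O)cc(-c2nn(CC#N)cc2-c2ccnc(-c3ccc(N(C)C)cc3)c2)c1`, 41900 nM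

Compound 1 returns only a limit of this assay, > 100000 nM, and not a number. Compound 2 likewise sits at a limit, > 100000 nM. Compound 3 gives a numerical reading of 41900 nM. For the measured compounds named here, the one measured step, an at least 2.3-fold lower number from compound 2 to compound 3 (0.37 log units; beyond the scatter), concerns a methoxy turned to hydroxyl and has no counterpart in the change to compound 4 `COc1cc(C)cc(-c2c(-c3ccnc(-c4ccc(C(C)=O)cc4)c3)cnn2CC#N)c1`, which is acetyl in place of dimethylamino on an aromatic carbon. Going by the values given here, no measured step therefore bears on this change, and a numerical reading is uncertain given (the limit of > 100000 nM in this assay, at which 2 of the 3 values shown sit). Compound 4 is expected near 100000 nM, within 30000 nM to 300000 nM, so the expected step is a number no higher from compound 1 to compound 4 (the limit leaves the size open), likely no movement beyond the scatter.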

Compound 4, concentration lethal to 50% of the cells: > 100000 nM
Compound 4 was reported as a limit; the forecaster's own chance of this, stated with the estimate: 60%; the middle value lies on the limit itself.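

Compound 1 and compound 4 both return only a limit, so no step can be read between them: the limit of > 100000 nM in this assay, at which 3 of the 4 values shown sit.

From the compounds shown here alone, whether acetyl in place of dimethylamino shifts the reading at all stays open.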